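Propargyl in Place of Cyclopentyl on the Amine Chain

This account rests on a few compounds, and the source may have more. Where it says the series, first, only, none or still open, it means among the compounds named here.

Compound 1 `Nc1ncnc2c1ncn2[C@@H]1O[C@H](CN(CC[C@H](N)C(=O)O)CC2CCC2)[C@@H](O)[C@H]1O` and compound 2 `Nc1ncnc2c1ncn2[C@@H]1O[C@H](CN(CC[C@H](N)C(=O)O)CC2CCCC2)[C@@H](O)[C@H]1O` share one core and differ only in the ring on the saturated chain carbon bound to the amine nitrogen. In an assay for inhibition of tRNA (cytosine(38)-C(5))-methyltransferase (Homo sapiens), with a stated time of 5 min, tested at 100 uM (on this read-out higher numbers stand for more inhibition at the one concentration tested (going by the name of the read-out) and lower numbers for less inhibition), compound 1 gives 32% and compound 2 gives 24.5%. Within the data shown here, the single step measured, a number 7.5 percentage points lower from compound 1 to compound 2 (within the scatter), lies within the scatter, so compound 2 stands level with compound 1 rather than apart from it. Compound 3 `C#CCN(CC[C@H](N)C(=O)O)C[C@H]1O[C@@H](n2cnc3c(N)ncnc32)[C@H](O)[C@@H]1O` carries the change (ethynyl in place of cyclopentyl on a saturated chain carbon bound to an amine nitrogen). Among the measured compounds shown here, no measured step bears on trading a ring for a group with no ring; the only step known, cyclopentyl in place of cyclobutyl, left the read-out unmoved beyond the scatter. With compound 2 as the anchor, compound 3 is therefore expected at an estimated 25%, with a wide range from 5% to 50%, which means an expected step of a number 0.5 percentage points higher from compound 2 to compound 3 (within the scatter).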

Compound 3, a percentage reported as inhibition, at one concentration (the size of the read-out at that concentration, not a potency): 72.2%
Estimate against measurement, compound 3: 47.2 percentage points below; measured number outside the range, above it.
By their numbers in this assay, from the lowest: compounds 2 and 1 (each within the scatter of the next); then compound 3.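

In this assay, the swap of one ring for another had left the read-out within the scatter, but this position on a saturated chain carbon bound to an amine nitrogen proves far from indifferent to what it carries: ethynyl in place of cyclopentyl gives a number 47.7 percentage points higher from compound 2 to compound 3 (beyond the scatter). Ethynyl in place of cyclobutyl gives a number 40.2 percentage points higher from compound 1 to compound 3 (beyond the scatter), so the rise holds against both compounds that carry a ring. Nothing available explains this rise.

The change removes the ring and brings in a triple bond at once, so the compounds shown cannot tell which of the two matters. From the compounds shown here alone, a propyl or allyl group in the same place would be needed to separate them, and whether a longer alkyne such as butynyl keeps the rise also remains open.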